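Working notes: from compound 2 to compound 3

The compounds below may be only part of what the source reports. "The series", "measured", "known", "first", "only" and "open" are said of these compounds alone.

Measured so far in a functional assay on PC-3 cells (Homo sapiens) for cytotoxicity, read by sulforhodamine B assay, with a stated time of 48 h; on this read-out higher numbers stand for weaker inhibition and lower numbers for stronger inhibition
- compound 1 `C[C@H]1CC[C@@H]2[C@@H](OC(=O)[C@]23CC(c2ccccc2[N+](=O)[O-])=NO3)[C@]2(C)C(=O)C=C[C@@]12O` gives 37000 nM
- compound 2 `C[C@H]1CC[C@@H]2[C@@H](OC(=O)[C@]23CC(c2ccccc2Cl)=NO3)[C@]2(C)C(=O)C=C[C@@]12O` gives 12000 nM

Compound 2 at 12000 nM holds the lower of the two numbers and is the stronger inhibitor of the pair in this assay. The next analogue is compound 3 `C[C@H]1CC[C@@H]2[C@@H](OC(=O)[C@]23CC(c2ccc(C#N)cc2)=NO3)[C@]2(C)C(=O)C=C[C@@]12O`, with 4-cyanophenyl in place of 2-chlorophenyl on a carbon with a double bond to nitrogen and the rest of the core unchanged.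

Within the data shown here, only one measured step bears on this change. It is a 3.1-fold lower number from compound 1 to compound 2 (0.49 log units; beyond the scatter), a modest step beyond the scatter, for chloro in place of nitro on an aromatic carbon. Among the measured compounds shown here, it shows that a change on the aromatic ring can shift the number in this pair, but no measured compound carries a 4-cyanophenyl group. For the measured compounds named here, with compound 1 at 37000 nM as the only other value, a step no larger than the measured one is expected, leaning toward a higher number and possibly not beyond the scatter. The estimated step is a 1.7-fold higher number from compound 2 to compound 3 (0.22 log units; within the scatter). Compound 3 is estimated at 20000 nM, with an expected range from 7000 nM to 60000 nM.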

Compound 3, half-maximal inhibitory concentration: 32000 nM
The estimate for compound 3 lay 1.6-fold (0.20 log units) below the measured number; the range from low to high includes it.
By their numbers in this assay, from the lowest: compound 2; then compounds 3 and 1 (each within the scatter of the next).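

In this assay, the aromatic group on the carbon with a double bond to nitrogen now has a second type of replacement: 4-cyanophenyl in place of 2-chlorophenyl gives a 2.7-fold higher number from compound 2 to compound 3 (0.43 log units; beyond the scatter) and so gives up the advantage held by compound 2 in this small set. Replacing 2-nitrophenyl with 4-cyanophenyl gives a 1.2-fold lower number from compound 1 to compound 3 (0.06 log units; within the scatter) and does not separate these two groups, so compound 2 alone stands apart from the other two, and the position responds to some aryl changes but not to all. No measurement is available that accounts for this difference between the aryl groups.

Compound 2 and compound 3 differ both in the substituent and in its place on the phenyl ring, so the compounds shown cannot tell which of the two sets the step. Also open, going by these compounds, is how this position reads with a phenyl ring bearing an amine or a carboxylic acid, or with a plain alkyl chain in place of the aromatic ring.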